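This account rests on a few compounds, and the source may have more. Where it says the series, first, only, none or still open, it means among the compounds named here.

Compound 1 `C=CCn1ncc2ccc(N/C(C)=C3\C(=O)C=C(C)OC3=O)cc21` and compound 3 `C=CCn1cc2ccc(N/C(C)=C3\C(=O)C=C(C)OC3=O)cc2n1` have the same atoms joined differently; the difference between the two cores is not broken down here. Compound 2 `CC1=CC(=O)/C(=C(/C)Nc2ccc3cnn(Cc4ccc(C)cc4)c3c2)C(=O)O1` arises from compound 1, and compound 4 `CC1=CC(=O)/C(=C(/C)Nc2ccc3cn(Cc4ccc(C)cc4)nc3c2)C(=O)O1` from compound 3, by one and the same change: 4-methylphenyl in place of vinyl on a saturated chain carbon bound to an aromatic nitrogen and (4-methylphenyl in place of vinyl on a saturated chain carbon bound to an aromatic nitrogen). In an ADME assay on RAW264.7 cells (Mus musculus) for cytotoxicity, read by resazurin assay, with a stated time of 48 h (a higher number here means that more compound is tolerated, a lower number that less compound is tolerated), compound 1 gives only a limit, > 100000 nM. In this assay compound 2 also gives only a limit, > 100000 nM. Compound 3 likewise gives only a limit, > 100000 nM. The step that the two limits leave unreadable from compound 1 to compound 2 cannot be sized, since both values sit at the limit of > 100000 nM in this assay, at which 3 of the 3 values shown sit. For compound 4 a step that the limit leaves unreadable from compound 3 to compound 4 is expected, resting on the unreadable a step that the two limits leave unreadable from compound 1 to compound 2. Compound 4 is therefore estimated at 200000 nM, most probably again reported only as a limit.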

Compound 4, half-maximal cytotoxic concentration: > 100000 nM
Compound 4 was reported as a limit; the forecaster's own chance of this, stated with the estimate: 85%; the middle value does not contradict the limit.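

In this assay compound 4 gives only a limit, > 100000 nM. No step from compound 3 to compound 4 can be read: the limit of > 100000 nM in this assay, at which 4 of the 4 values shown sit.

The compounds shown leave open at what concentration any of them becomes cytotoxic, and whether allyl to 4-methylbenzyl changes tolerance on either core.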